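The source may report more compounds than this note shows. Statements on the series, on what has been measured and on what is new or still open speak of the compounds shown alone.

Compound 1 `Cc1c(CC(=O)O)c2ccsc2n1S(=O)(=O)c1ccccc1` gives 2750 nM in an assay on HEK293 cells for displacement of a labelled ligand from prostaglandin D2 receptor 2 (Homo sapiens); on this read-out lower numbers stand for stronger inhibition and higher numbers for weaker inhibition; compound 2 `Cc1c(CC(=O)O)c2ccsc2n1S(=O)(=O)c1ccc(C(F)(F)F)cc1` gives 1130 nM in this assay.

Among the compounds with values here, compound 2 holds the lowest of these two numbers, and its only neighbour is compound 1, the step being a 2.4-fold lower number from compound 1 to compound 2 (0.39 log units; beyond the scatter). Compound 3 `Cc1c(CC(=O)O)c2ccsc2n1S(=O)(=O)c1ccc(S(C)(=O)=O)cc1` differs from compound 2 by methylsulfonyl in place of trifluoromethyl on an aromatic carbon. Within the data shown here, only that single step bears on this change, and it concerned a different group entering in place of hydrogen, so it offers limited guidance. Compound 3 is therefore expected to stay near compound 2, with a 1.3-fold higher number from compound 2 to compound 3 (0.12 log units; within the scatter) in this assay. The estimate for compound 3 is 1500 nM, with a range from 500 nM to 5000 nM.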

Compound 3, half-maximal inhibitory concentration: 90 nM
Compound 3: middle estimate off by 17-fold (1.22 log units), on the high side; the whole stated range lies above it.
By their numbers in this assay, from the lowest: compound 3; then compound 2; then compound 1.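

In this assay, the group on this aromatic carbon, para to a large group, matters far more than compound 2 suggested: the change from trifluoromethyl to methylsulfonyl gives a 13-fold lower number from compound 2 to compound 3 (1.10 log units; beyond the scatter) even though both groups have 4 heavy atoms. Measured against hydrogen, methylsulfonyl gives a 31-fold lower number from compound 1 to compound 3 (1.49 log units; beyond the scatter) and so goes well beyond what trifluoromethyl achieved. No measurement shown here accounts for the difference between the two groups.

The compounds shown leave open whether a sulfonamide or a carboxylic acid on this carbon would give a similarly low number. They also leave open whether the methyl of the methylsulfonyl group could give way to an ethyl or cyclopropyl group.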